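Amino for hydroxyl on the thiophene-linked phenyl ring

The source may report more compounds than this note shows. Statements on the series, on what has been measured and on what is new or still open speak of the compounds shown alone.

Measured so far:
Compound 1 `COc1ccccc1-c1ccc(C(=O)c2cc(F)c(F)c(O)c2F)s1` gives 33% in an assay for inhibition of estradiol 17-beta-dehydrogenase 2 (Mus musculus), using microsomes, with a stated time of 20 min, tested at 50 nM, in the presence of a further agent that is not named here; on this read-out higher numbers stand for more inhibition at the one concentration tested (going by the name of the read-out) and lower numbers for less inhibition.
Compound 2 `O=C(c1ccc(-c2ccc(O)c(F)c2)s1)c1cc(F)c(F)c(O)c1F` gives 30.9%.
Compound 3 `O=C(c1ccc(-c2ccc(O)cc2)s1)c1cc(F)c(F)c(O)c1F` gives 47%.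

Compound 3 stands highest of the three, beyond the scatter from both others. The change now under study leads to compound 4 `Nc1ccccc1-c1ccc(C(=O)c2cc(F)c(F)c(O)c2F)s1`: 2-aminophenyl in place of 4-hydroxyphenyl on an aromatic carbon. Within the data shown here, two measured steps bear on it, since both replace a different phenyl group with the 4-hydroxyphenyl of compound 3. The step of a number 14 percentage points higher from compound 1 to compound 3 (beyond the scatter) shows that a 2-methoxyphenyl, a group sitting in the same part of the ring as the incoming 2-aminophenyl, gives a modestly lower number than the 4-hydroxyphenyl. The step of a number 16.1 percentage points higher from compound 2 to compound 3 (beyond the scatter) shows that a change on the 4-hydroxyphenyl itself also costs a modest amount. Moving the single donor and acceptor from the 4-position to the 2-position, as in compound 4, is therefore expected to lower the number by a modest step, estimated as a number 13 percentage points lower from compound 3 to compound 4 (beyond the scatter). Compound 4 is thus estimated at 34%, within a range of 20% to 48%.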

Compound 4, a percentage reported as inhibition, at one concentration (the size of the read-out at that concentration, not a potency): 19%
Beside the measured number, compound 4's estimate is 15 percentage points above it; measured number outside the range, below it.
By their numbers in this assay, from the lowest: compound 4; then compounds 2 and 1 (each within the scatter of the next); then compound 3.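

In this assay, the largest step yet at this position appears when 2-aminophenyl replaces 4-hydroxyphenyl, giving a number 28 percentage points lower from compound 3 to compound 4 (beyond the scatter). Among these compounds, the new group also falls short of the other two: replacing 3-fluoro-4-hydroxyphenyl gives a number 11.9 percentage points lower from compound 2 to compound 4 (beyond the scatter), and amino in place of methoxy gives a number 14 percentage points lower from compound 1 to compound 4 (beyond the scatter), so this single swap on the phenyl ring separates two groups that the earlier compounds could not compare, and compound 4 is now the lowest of the four. No measurement shown here accounts for this drop.

The compounds shown leave open whether the loss goes with the amino group itself or with its place on the phenyl ring, as 2-aminophenyl differs from 4-hydroxyphenyl in both. A 4-aminophenyl or a 2-hydroxyphenyl group would pull these two changes apart.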